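The source may report more compounds than this note shows. Statements on the series, on what has been measured and on what is new or still open speak of the compounds shown alone.

Measured so far:
compound 1, `COc1ccc(-c2cc(/C=C/C(=O)c3ccc(N)cc3)[nH]n2)cc1`: 97%
compound 2, `COc1ccc(C(=O)/C=C/c2cc(-c3cc(OC)c(OC)c(OC)c3)n[nH]2)cc1OC`: 96%
compound 3, `COc1ccc(-c2cc(/C=C/C(=O)c3ccc(N)cc3)[nH]n2)cc1OC`: 95%

All three were tested in a functional assay on U-251 cells (Homo sapiens) for cytotoxicity, read by sulforhodamine B assay, with a stated time of 48 h, tested at 0.01 uM; on this read-out lower numbers stand for a stronger effect and higher numbers for a weaker effect at the one concentration tested. Compound 3 differs from compound 1 by a single change, (methoxy in place of hydrogen on an aromatic carbon), and that change gave a number 2 percentage points lower from compound 1 to compound 3 (within the scatter). Compound 2 carries a different core; how its core differs from that of compound 1 is not broken down here. Its value lies within the scatter of both compound 1 and compound 3, so the three numbers cannot be told apart.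

Compound 4, `COc1cc(C(=O)/C=C/c2cc(-c3cc(OC)c(OC)c(OC)c3)n[nH]2)cc(OC)c1OC`, has not yet been measured. It differs from compound 2 by methoxy in place of hydrogen on an aromatic carbon. Going by the values given here, this is the same kind of change as the one from compound 1 to compound 3, though the surroundings are not identical: in compound 4 the place is described as meta to a methoxy group as well, which the place in compound 3 is not.

The step in this assay is expected to be small, no change at the digits printed from compound 2 to compound 4 (within the scatter), because the same kind of change gave a number 2 percentage points lower from compound 1 to compound 3 (within the scatter) and all three measured numbers sit close together. On that basis compound 4 is expected to give about 96%, with a likely range from 88% to 103%.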

Compound 4, a percentage reported as activity, at one concentration (the size of the read-out at that concentration, not a potency): 96%
Beside the measured number, compound 4's estimate shows no gap at the digits printed; measured number inside the range.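

Putting a methoxy group in place of a hydrogen on an aromatic carbon of compound 2 gave, in this assay, no change at the digits printed from compound 2 to compound 4 (within the scatter) and so left the number where it was. Set beside the earlier case, the change behaves alike on both cores as far as this read-out can tell, with the two steps not distinguishable from each other: the same change on two cores in this assay, a number 2 percentage points lower (within the scatter) from compound 1 to compound 3 and no change at the digits printed (within the scatter) from compound 2 to compound 4, 2 percentage points apart, within the scatter of two such steps

Going by these compounds alone, this shows only that the change moved the number by no more than the usual scatter on these two cores, at one concentration, and in somewhat different surroundings, since the new methoxy in compound 4 sits ortho to a methoxy group and meta to another. It does not show that the change has no effect in general, or that it would carry over in the same way to a compound with a clearly stronger effect, since none of the compounds shown can be told apart from the others.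

The compounds shown leave open what a fluorine atom, a carboxylic acid or a longer chain such as ethoxy would do on that aromatic carbon. They also leave open how these compounds compare at other concentrations, where differences between the two cores might become readable.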